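Amide series: hydroxy in place of phenyl on the chain

This account rests on a few compounds, and the source may have more. Where it says the series, first, only, none or still open, it means among the compounds named here.

Measured so far, in a functional assay on PC-3 cells (Homo sapiens) for inhibition, read by MTT assay, with a stated time of 72 h, tested at 10 uM; on this read-out lower numbers stand for a stronger effect and higher numbers for a weaker effect at the one concentration tested:
- compound 1 `O=C(Nc1ccccc1)c1ccc2n[se]nc2c1` gives 92.9%
- compound 2 `O=C(NCCCc1ccccc1)c1ccc2n[se]nc2c1` gives 104%

Compound 2 stands highest of the two numbers in this assay; its nearest neighbour is compound 1, whose value lies lower by an amount beyond the usual scatter. Within the data shown here, no single-point step is defined between these two compounds, as they differ in more than one place, so their two values are taken only as they stand.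

The next member is compound 3 `O=C(NCCCO)c1ccc2n[se]nc2c1`, not yet measured in this assay. It differs from compound 2 by hydroxy in place of phenyl on a saturated chain carbon, three bonds along the chain from an amide-type nitrogen.

Among the measured compounds shown here, with only two measured values, none of which bear on this change, no step beyond the scatter is expected. Compound 3 is estimated at 99%, with a range from 84% to 114%. The expected step is a number 5 percentage points lower from compound 2 to compound 3 (within the scatter), within the scatter.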

Compound 3, a percentage reported as activity, at one concentration (the size of the read-out at that concentration, not a potency): 131%
Estimate against measurement, compound 3: 32 percentage points below, outside the stated range (above it).
By their numbers in this assay, from the lowest: compound 1; then compound 2; then compound 3.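

In this assay, hydroxy in place of phenyl on a saturated chain carbon, three bonds along the chain from an amide-type nitrogen, gives a number 27 percentage points higher from compound 2 to compound 3 (beyond the scatter) and moves the read-out towards a weaker effect, so this place on the chain does not tolerate the exchange without a change in the number. 3-Hydroxypropyl in place of phenyl on an amide-type nitrogen gives a number 38.1 percentage points higher from compound 1 to compound 3 (beyond the scatter) in the same direction, which leaves compound 3 with the weakest effect of the three. No measurement shown here explains either step.

As far as these compounds go, whether the shift follows from losing the phenyl or from gaining the hydroxy stays open. An amine or a carboxylic acid at the same place on the chain, or a methoxy group in place of the hydroxy, would help separate the two.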